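The source may report more compounds than this note shows. Statements on the series, on what has been measured and on what is new or still open speak of the compounds shown alone.

Measured compounds:
- compound 1, `NC(=O)c1ccc2c(c1)S(=O)(=O)C=C2`, 3550 nM
- compound 2, `COc1ccc(NC(=O)c2ccc3c(c2)S(=O)(=O)C=C3)cc1`, 4 nM

In a functional assay on CCRF-CEM cells (Homo sapiens) for cytotoxicity, read by MTT assay, with a stated time of 72 h (a lower number here means a stronger inhibitor of growth, a higher number a weaker inhibitor of growth), compound 1 gives 3550 nM, the highest of the two numbers, so of the two it is the weaker inhibitor of growth. Its nearest neighbour is compound 2, with 4 nM; the gap between compound 1 and compound 2 is far beyond the scatter of the assay, and it coincides with the amide hydrogen of compound 1 being replaced by a methoxyphenyl group on the nitrogen. Going by the values given here, no step between measured compounds that differ in only one place is available here, so the single pair of values is all there is to go on.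

Compound 3, `CCCCNC(=O)c1ccc2c(c1)S(=O)(=O)C=C2`, has not yet been measured in this assay. It differs from compound 1 by butyl in place of hydrogen on an amide-type nitrogen. Among the compounds with values here, the only comparison at hand, compound 1 against compound 2, shows that filling the same amide nitrogen with a larger group went with a much lower number. A butyl group is a different kind of substituent, so the move from compound 1 to compound 3 is expected to lower the number, but by less than the measured pair suggests, and with wide uncertainty: an estimated 14-fold lower number from compound 1 to compound 3 (1.15 log units; beyond the scatter). For compound 3 the expected value is 250 nM, within a range of 30 nM to 2000 nM.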

Compound 3, concentration for 50% growth inhibition: 280 nM
For compound 3 the middle estimate is 1.1-fold (0.05 log units) below the measured one, and the stated range covers the measured number.
By their numbers in this assay, from the lowest: compound 2; then compound 3; then compound 1.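

Butyl in place of the amide hydrogen gives a 13-fold lower number from compound 1 to compound 3 (1.10 log units; beyond the scatter) in this assay and so the lower number at this amide nitrogen is no longer tied to a single substituent. Before this result the only group seen on that nitrogen was the methoxyphenyl group of compound 2, which left it unclear whether a ring was needed; butyl has no ring, and the number still falls by a step beyond the scatter. A ring is therefore not required for a large part of the gain, although compound 3 at 280 nM still sits well above compound 2 at 4 nM in the printed values.

Still open, on these data alone, is how the number follows the size and shape of the group on this nitrogen: a methyl group, a longer chain such as octyl, a branched tert-butyl group, a plain phenyl ring without the methoxy group, or a chain ending in an amine or a carboxylic acid would each test a different part of that question. Going by these compounds alone, nothing measured so far explains why these groups go with lower numbers.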